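An Aryl Sulfonyl Group Replaces a Carboxyalkyl Acyl Group

The source may report more compounds than this note shows. Statements on the series, on what has been measured and on what is new or still open speak of the compounds shown alone.

Three measured compounds share one core and differ only at an amine nitrogen. Compound 1 `N#CC1=C(N)N(c2ccc(S(N)(=O)=O)cc2)C2=C(C(=O)CCC2)C1c1ccc(Cl)cc1Cl` gives 25 ug/mL in a functional assay on Ehrlich cells (Mus musculus) for cytotoxicity, read by trypan blue exclusion, with a stated time of 2 h; on this read-out higher numbers stand for weaker inhibition and lower numbers for stronger inhibition. Compound 2 `N#CC1=C(NC(=S)Nc2ccc(Cl)cc2)N(c2ccc(S(N)(=O)=O)cc2)C2=C(C(=O)CCC2)C1c1ccc(Cl)cc1Cl` gives 40 ug/mL, and compound 3 `N#CC1=C(NC(=O)CCC(=O)O)N(c2ccc(S(N)(=O)=O)cc2)C2=C(C(=O)CCC2)C1c1ccc(Cl)cc1Cl` gives 50 ug/mL, the highest of the three numbers, though each step to it stays within the scatter: a 2.0-fold higher number from compound 1 to compound 3 (0.30 log units; within the scatter) and a 1.3-fold higher number from compound 2 to compound 3 (0.10 log units; within the scatter). Compound 4 `N#CC1=C(NS(=O)(=O)c2ccc([N+](=O)[O-])cc2)N(c2ccc(S(N)(=O)=O)cc2)C2=C(C(=O)CCC2)C1c1ccc(Cl)cc1Cl` is not yet measured; it differs from compound 3 by (4-nitrophenyl)sulfonyl in place of (2-carboxyethyl)carbonyl on an amine nitrogen. Among the measured compounds shown here, the steps that bear on this, a 1.6-fold higher number from compound 1 to compound 2 (0.20 log units; within the scatter) and a 1.3-fold higher number from compound 2 to compound 3 (0.10 log units; within the scatter), each put a group holding one aromatic ring on this nitrogen, and neither moved the number beyond the scatter. Compound 4 is therefore expected to show no step beyond the scatter, a 1.3-fold lower number from compound 3 to compound 4 (0.10 log units; within the scatter). The estimate for compound 4 is 40 ug/mL, with a range from 18 ug/mL to 90 ug/mL.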

Compound 4, half-maximal inhibitory concentration: 20 ug/mL
Beside the measured number, compound 4's estimate is 2.0-fold (0.30 log units) above it; the range from low to high includes it.
By their numbers in this assay, from the lowest: compounds 4, 1, 2 and 3 (each within the scatter of the next, the first and the last beyond it).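

Among the compounds shown here, this is the first step on this amine nitrogen in this assay to lie beyond the scatter (a 2.5-fold lower number from compound 3 to compound 4 (0.40 log units; beyond the scatter)). Compound 4 nevertheless stays within the scatter of the other two compounds (a 2.0-fold lower number from compound 2 to compound 4 (0.30 log units; within the scatter); a 1.3-fold lower number from compound 1 to compound 4 (0.10 log units; within the scatter)), so only the two ends of the series are separated. Nothing measured here gives a reason for the step.

The compounds shown do not tell whether the sulfonyl link or the 4-nitrophenyl ring matters more. Methylsulfonyl or plain phenylsulfonyl on this nitrogen would pull the two apart.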